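Methylpyridinyl back in place of methoxyphenyl on the amine

A few compounds are considered here, and "the series" means these few. Any claim that something is new, unique, unknown or untested is made for them only; others in the source may bear on it.

Working notes on the series. In an in vivo ADME assay on the whole organism (strain Sprague-Dawley) for metabolic stability, with Rattus norvegicus as the target, at a dose of 5 mg/kg by the intravenous route (on this read-out higher numbers stand for a longer-lived compound and lower numbers for a shorter-lived compound), compound 3 `COc1ccccc1CNC1(CCC(C)(C)C)C(=O)C(C2=NS(=O)(=O)c3cc(NS(C)(=O)=O)ccc3N2)=C(O)c2ccccc21` gives 3.2 h, the highest of the three numbers measured. Compound 2 `CC(C)CC[C@@]1(NCc2ccccc2)C(=O)C(C2=NS(=O)(=O)c3cc(NS(C)(=O)=O)ccc3N2)=C(O)c2ccccc21` gives 1.7 h, which lies within the scatter of compound 3. Compound 1 `Cc1ccc(CNC2(CCC(C)(C)C)C(=O)C(C3=NS(=O)(=O)c4cc(NS(C)(=O)=O)ccc4N3)=C(O)c3ccccc32)cn1` gives 0.5 h, and its gap to compound 3 is beyond the scatter.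

Compound 4 `Cc1cccc(CNC2(CCC(C)(C)C)C(=O)C(C3=NS(=O)(=O)c4cc(NS(C)(=O)=O)ccc4N3)=C(O)c3ccccc32)n1` is not yet measured. It differs from compound 3 in one place: 6-methylpyridin-2-yl in place of 2-methoxyphenyl on a saturated chain carbon bound to an amine nitrogen. Among the measured compounds shown here, one measured step bears on this change and runs in the opposite sense, a 6.4-fold higher number from compound 1 to compound 3 (0.81 log units; beyond the scatter), a modest rise when a methylpyridinyl gave way to the 2-methoxyphenyl. Compound 4 reverses that exchange, though with 6-methylpyridin-2-yl rather than the 6-methylpyridin-3-yl of compound 1, so the two changes are not identical and the size of the effect is less certain than the measured step.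

A fall beyond the scatter is therefore expected, a 3.2-fold lower number from compound 3 to compound 4 (0.51 log units; beyond the scatter), landing somewhere between compound 1 and compound 3. Compound 4 is estimated at 1 h, with a range of 0.4 h to 2.5 h.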

Compound 4, half-life: 1 h
Compound 4: the middle estimate sits on the measured number at the digits printed; measured number inside the range.
By their numbers in this assay, from the lowest: compounds 1, 4, 2 and 3 (each within the scatter of the next, the first and the last beyond it).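

In this assay the step of a 3.2-fold lower number from compound 3 to compound 4 (0.51 log units; beyond the scatter) shows that a second methylpyridinyl, 6-methylpyridin-2-yl, also gives a shorter half-life than 2-methoxyphenyl on this saturated chain carbon bound to an amine nitrogen, so the earlier loss no longer rests on 6-methylpyridin-3-yl alone. The exchange between the two methylpyridinyl groups, a 2.0-fold higher number from compound 1 to compound 4 (0.30 log units; within the scatter), does not separate them, and in these compounds the choice of methylpyridinyl isomer matters less here than the exchange of either for 2-methoxyphenyl. No measurement at hand speaks to the cause of either step.

The compounds shown leave open whether the ring nitrogen or the loss of the methoxy group carries the fall, as the two change together in each pair. A 2-methylphenyl or a methoxypyridinyl group in this place would pull them apart.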